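The source may hold more compounds than are shown below. What is called first, only, known or untested is meant among the compounds shown, and "the series" means these compounds.

Compound 1 `COC1=C(C)C(=O)/C(=C(O)/C=C/c2ccc(C)cc2)C(=O)C1(C)C` is a small molecule whose cytotoxic effect was measured in a functional assay on A-431 cells (Homo sapiens) for cytotoxicity (a higher number here means that more compound is needed for the effect, a lower number that less compound is needed), where compound 1 gives 5.1 ug/mL. Compound 2 `CCc1ccc(/C=C/C(O)=C2/C(=O)C(C)=C(OC)C(C)(C)C2=O)cc1` differs from it in one place only, by methyl in place of hydrogen on a saturated chain carbon bound to an aromatic carbon, and in this assay compound 2 gives 12 ug/mL. That single change produced a 2.4-fold higher number from compound 1 to compound 2 (0.37 log units; beyond the scatter).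

Compound 3 `CCC1=C(OC)C(CC)(CC)C(=O)C(C(=O)/C=C/c2ccc(C)cc2)=C1O` is built on a different core; how its core differs from that of compound 1 is not broken down here. In this assay compound 3 gives 10.3 ug/mL, which lies within the usual scatter of the number for compound 2, while against compound 1 it stands as a higher number, beyond the scatter.

Compound 4 `CCC1=C(OC)C(CC)(CC)C(=O)C(C(=O)/C=C/c2ccc(CC)cc2)=C1O` is not yet measured. It differs from compound 3 by methyl in place of hydrogen on a saturated chain carbon bound to an aromatic carbon, the same change that separates compound 1 from compound 2. Resting on the earlier step of a 2.4-fold higher number from compound 1 to compound 2 (0.37 log units; beyond the scatter), a comparable step is expected, a 2.0-fold higher number from compound 3 to compound 4 (0.31 log units; beyond the scatter). For compound 4 the estimated number in this assay is 21 ug/mL, expected to fall between 9 ug/mL and 45 ug/mL.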

Compound 4, concentration for half-maximal effect: 9.8 ug/mL
Compound 4: the middle estimate sits 2.1-fold (0.33 log units) above what was measured, within the range that was stated.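

Going from 4-methylphenyl to 4-ethylphenyl on the second core gives a 1.1-fold lower number from compound 3 to compound 4 (0.02 log units; within the scatter) in this assay and so no clear step, even though the same added methyl gave a step beyond the scatter on the first core. Set side by side, the two results still cannot be told apart: the same change on two cores in this assay, a 2.4-fold higher number (0.37 log units; beyond the scatter) from compound 1 to compound 2 and a 1.1-fold lower number (0.02 log units; within the scatter) from compound 3 to compound 4, 2.5-fold (0.39 log units) apart, within the scatter of two such steps. Within the data shown here, this means the data do not show that the core changes the effect of this methyl, and they do not show that the step carries over at the same size either, since only two pairs of compounds are available and one step is indistinguishable from no change.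

The compounds shown leave open whether a further pair on either core would settle how well this change transfers from one core to another. They also leave open what a longer chain such as propyl, or an amine or a carboxylic acid, would do in place of the ethyl group on each core.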